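Removing the end group from a potent side chain

The source may hold more compounds than are shown below. What is called first, only, known or untested is meant among the compounds shown, and "the series" means these compounds.

Compound 2 `CCC[C@H]1C[C@@H](OC)C/C(C)=C\[C@@H]2C[C@@H](OC(=O)/C=C\CCc3coc(/C=C\CNC(=O)OC)n3)C[C@H](CC(=O)O1)O2` gives 0.5 nM in a functional assay on A549 cells (Homo sapiens) for antiproliferative activity, read by WST assay, with a stated time of 120 h (on this read-out higher numbers stand for weaker inhibition and lower numbers for stronger inhibition), and holds the lowest number shown. Compound 3 `CCC[C@H]1C[C@@H](OC)C/C(C)=C\[C@@H]2C[C@@H](OC(=O)/C(C)=C\CCc3coc(/C=C\CNC(=O)OC)n3)C[C@H](CC(=O)O1)O2` gives 2.5 nM here, a higher number, beyond the usual scatter. Compound 1 `CCC[C@H]1C[C@@H](OC)C/C(C)=C\[C@@H]2C[C@@H](OC(=O)CCCCc3coc(CCCNC(=O)OC)n3)C[C@H](CC(=O)O1)O2` stands at > 10000 nM as a limit of the assay and not a number. Compound 4 `C/C=C\c1nc(CC/C=C\C(=O)O[C@H]2C[C@@H]3CC(=O)O[C@@H](CCC)C[C@@H](OC)C/C(C)=C\[C@H](C2)O3)co1` departs from compound 2 by one change hydrogen in place of (methoxycarbonyl)amino on a saturated chain carbon bound to a double-bonded chain carbon in which hydrogen takes the place of (methoxycarbonyl)amino on a saturated chain carbon bound to a double-bonded chain carbon. Within the data shown here, no measured pair shows this change alone. Compound 2 gives 0.5 nM, which leaves mostly room to rise, so weaker inhibition is expected. The estimated step of a 60-fold higher number from compound 2 to compound 4 (1.78 log units; beyond the scatter) in this assay lies beyond the scatter. For compound 4 the expected value is 30 nM within an estimated range of 3 nM to 500 nM in this assay for now.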

Compound 4, half-maximal inhibitory concentration: 740 nM
Compound 4: the middle estimate sits 25-fold (1.39 log units) below what was measured; the measured number lies above the stated range.
By their numbers in this assay, from the lowest: compound 2; then compound 3; then compound 4. At a limit, above all of these: compound 1.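

Putting hydrogen in place of (methoxycarbonyl)amino on a saturated chain carbon bound to a double-bonded chain carbon gives a 1500-fold higher number from compound 2 to compound 4 (3.17 log units; beyond the scatter) in this assay. Among these compounds, all the earlier compounds carried this end group, so only now is it clear that much of the potency of compound 2 depends on it. Nothing shown here explains why the loss is so large.

As far as these compounds go, whether a simple amine, a hydroxyl group or a longer chain at this place would recover the potency remains open. From the compounds shown here alone, the size of this step on the side chain of compound 3 also remains open.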